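The source may report more compounds than this note shows. Statements on the series, on what has been measured and on what is new or still open speak of the compounds shown alone.

Measured compounds in an ADME assay on HEK293 cells (Homo sapiens) for antiproliferative activity, read by MTT assay; a higher number here means a weaker inhibitor, a lower number a stronger inhibitor:

Compound 1, `Cc1ccc(/C=N/NC(=O)c2oc3nc(-c4ccccc4)cc(C(F)(F)F)c3c2N)cc1`, gives 69000 nM.
Compound 2, `CCCNC(=O)c1oc2nc(-c3ccccc3)cc(C(F)(F)F)c2c1N`, gives 81000 nM.
Compound 3, `Cc1ccc(/C=N/NC(=O)c2oc3nc(-c4cccs4)cc(C(F)(F)F)c3c2N)cc1`, gives 78000 nM.

All three numbers fall close together. Compound 1 and compound 2 differ by one change, (a group of 3 heavy atoms (3 carbon; no ring) in place of a group of 9 heavy atoms (8 carbon, 1 nitrogen; one six-membered aromatic ring of carbon only), on an amide-type nitrogen), and that change made a step of a 1.2-fold higher number from compound 1 to compound 2 (0.07 log units; within the scatter). Compound 1 and compound 3 differ only in the group on the core, (thiophen-2-yl in place of phenyl on an aromatic carbon), and that change made a step of a 1.1-fold higher number from compound 1 to compound 3 (0.05 log units; within the scatter). Neither step stands out from the scatter of the method, so within this set none of the three compounds can be called stronger or weaker than another.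

Compound 4, `CCCNC(=O)c1oc2nc(-c3cccs3)cc(C(F)(F)F)c2c1N`, has not yet been measured in this assay. It differs from compound 3 by a group of 3 heavy atoms (3 carbon; no ring) in place of a group of 9 heavy atoms (8 carbon, 1 nitrogen; one six-membered aromatic ring of carbon only), on an amide-type nitrogen. Going by the values given here, this is the same change as the one from compound 1 to compound 2, made on the same kind of amide-type nitrogen with a carbonyl carbon as its other neighbour; the two cores differ by thiophen-2-yl in place of phenyl on an aromatic carbon. Because the step of a 1.2-fold higher number from compound 1 to compound 2 (0.07 log units; within the scatter) was small, compound 4 is expected to sit near compound 3, with an estimated step of a 1.2-fold higher number from compound 3 to compound 4 (0.06 log units; within the scatter). The expectation rests on one pair of compounds only, compound 1 and compound 2, so the range is kept broad. Compound 4 is estimated at 90000 nM, between 45000 nM and 180000 nM.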

Compound 4, half-maximal inhibitory concentration: 64000 nM
Compound 4: the middle estimate sits 1.4-fold (0.15 log units) above what was measured; measured number inside the range.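

In this assay the propyl change on the amide-type nitrogen gave a 1.2-fold lower number from compound 3 to compound 4 (0.09 log units; within the scatter) and stands beside the earlier step on the other core as follows: the same change on two cores in this assay, a 1.2-fold higher number (0.07 log units; within the scatter) from compound 1 to compound 2 and a 1.2-fold lower number (0.09 log units; within the scatter) from compound 3 to compound 4, 1.4-fold (0.16 log units) apart, within the scatter of two such steps.
The change to thiophen-2-yl gave a 1.3-fold lower number from compound 2 to compound 4 (0.10 log units; within the scatter) and compares in the same way: the same change on two cores in this assay, a 1.1-fold higher number (0.05 log units; within the scatter) from compound 1 to compound 3 and a 1.3-fold lower number (0.10 log units; within the scatter) from compound 2 to compound 4, 1.4-fold (0.16 log units) apart, within the scatter of two such steps.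
Going by these compounds alone, both changes therefore behave alike on the two cores, in that each stays within the scatter on both and the paired steps do not differ beyond it, but this shows only that neither change moves the number measurably in these compounds, and it cannot show whether a change with a real effect would carry from one core to the other.

All four compounds keep the trifluoromethyl group and the amine on the shared core, and their numbers lie close together, so the compounds shown leave open whether any other change would move the number at all. On these data alone, whether a longer chain or a chain ending in an amine in place of propyl, or a pyridine ring in place of phenyl, would give a step beyond the scatter also remains open.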